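Oxime ester series: shortening the acyl group on the oxime oxygen

A few compounds are considered here, and "the series" means these few. Any claim that something is new, unique, unknown or untested is made for them only; others in the source may bear on it.

Values measured in a functional assay (blood) for inhibition, with Homo sapiens as the target; on this read-out lower numbers stand for stronger inhibition and higher numbers for weaker inhibition:

compound 1 `C/C(=N\OC(=O)C(C)(C)C)c1ccc(Sc2cc(F)cc(C3CCOCC3)c2)cc1`: 40 nM
compound 2 `CS/C(=N\O)c1ccc(Sc2cc(F)cc(C3CCOCC3)c2)cc1`: 190 nM
compound 3 `COC(=O)c1cc(CO/N=C(\C)c2ccc(Sc3cc(F)cc(C4CCOCC4)c3)cc2)on1`: 100 nM

Compound 3 stands second highest of the three numbers; compound 2 lies within the scatter of it, while compound 1 sits beyond it, a 2.5-fold higher number from compound 1 to compound 3 (0.40 log units; beyond the scatter). Compound 4 `CC(=O)O/N=C(\C)c1ccc(Sc2cc(F)cc(C3CCOCC3)c2)cc1` is the next entry: acetyl in place of (3-(methoxycarbonyl)-1,2-oxazol-5-yl)methyl on an oxygen. The step that bears on it is the one at the same oxygen, a 2.5-fold higher number from compound 1 to compound 3 (0.40 log units; beyond the scatter), where (3-(methoxycarbonyl)-1,2-oxazol-5-yl)methyl stood in place of (tert-butyl)carbonyl; the change from compound 1 to compound 2 sits elsewhere and is only background. Acetyl brings back a small carbonyl group as in compound 1, so a lower number than compound 3 is expected, a 1.7-fold lower number from compound 3 to compound 4 (0.22 log units; within the scatter). Compound 4 is estimated at 60 nM in this assay, with a range of 30 nM to 130 nM.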

Compound 4, half-maximal inhibitory concentration: 50 nM
Compound 4: middle estimate off by 1.2-fold (0.08 log units), on the high side; the range from low to high includes it.
By their numbers in this assay, from the lowest: compounds 1, 4, 3 and 2 (each within the scatter of the next, the first and the last beyond it).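

In this assay, methyl and tert-butyl on the carbonyl carbon cannot be told apart, a 1.3-fold higher number from compound 1 to compound 4 (0.10 log units; within the scatter), so the size of this alkyl group does not register between these two compounds. Acetyl also stays unresolved from the group it replaces, a 2.0-fold lower number from compound 3 to compound 4 (0.30 log units; within the scatter). Only the larger change clears the scatter, a 3.8-fold lower number from compound 2 to compound 4 (0.58 log units; beyond the scatter), and that change involves more than the acyl group.

Nothing available explains these numbers. From the compounds shown here alone, it remains open whether a longer acyl chain, or an amine on the carbonyl carbon, would stay within the scatter of compound 4.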